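Adding phenylsulfanyl to the acetamido group of compound 3

The source may report more compounds than this note shows. Statements on the series, on what has been measured and on what is new or still open speak of the compounds shown alone.

compound 1 `COc1ccc(-c2nc(/N=C(\N)N(C)C)sc2-c2ccc(OC)cc2)cc1` gives 37 nM in the assay
compound 2 `COc1ccc(-c2nc(/N=C(\N)[N+]3(C)CCCCC3)sc2-c2ccc(OC)cc2)cc1` gives > 1000 nM in the assay
compound 3 `COc1ccc(-c2nc(CNC(C)=O)sc2-c2ccc(OC)cc2)cc1` gives 15 nM in the assay

In a functional assay with Oryctolagus cuniculus as the target (on this read-out higher numbers stand for weaker inhibition and lower numbers for stronger inhibition), compound 3 has the lower of the two exact values at 15 nM and so sits at the favourable end of this small set. Compound 2 at > 1000 nM is reported only as a limit of the assay. The gap to the other exact value is a 2.5-fold lower number from compound 1 to compound 3 (0.39 log units; beyond the scatter) and counts as modest, while the gap from the limit is an at least 66-fold lower number from compound 2 to compound 3 (1.82 log units; beyond the scatter) and counts as large.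

Compound 4 `COc1ccc(-c2nc(CNC(=O)CSc3ccccc3)sc2-c2ccc(OC)cc2)cc1` keeps the core of compound 3 and changes one place phenylsulfanyl in place of hydrogen on a saturated chain carbon bound to a carbonyl carbon so that a methyl becomes a (phenylsulfanyl)methyl. Among the compounds with values here, no measured step makes this exact change, so the guidance is indirect. Enlarging a group gave an at least 27-fold higher number from compound 1 to compound 2 (1.43 log units; beyond the scatter) as a large rise, although that is a single and quite different case. Exchanging the whole group on an aromatic carbon gave a 2.5-fold lower number from compound 1 to compound 3 (0.39 log units; beyond the scatter) as a much smaller shift. A moderate rise is therefore expected, with the estimated step being a 3.3-fold higher number from compound 3 to compound 4 (0.52 log units; beyond the scatter) in this assay on this limited evidence. Compound 4 is estimated at 50 nM with 10 nM to 300 nM as the expected range.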

Compound 4, half-maximal inhibitory concentration: < 100 nM
Compound 4: a limit, no number; the forecaster's own chance of this, stated with the estimate: 10%; the middle value is on the limit's open side.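

In this assay compound 4 gives < 100 nM, which is a limit and not a number. The step from compound 3 to compound 4 therefore cannot be read. The compounds shown leave open whether phenylsulfanyl in place of hydrogen on this saturated chain carbon raises the number, lowers it or leaves it within the usual scatter.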